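This account rests on a few compounds, and the source may have more. Where it says the series, first, only, none or still open, it means among the compounds named here.

Values in a functional assay on EL4 cells (Mus musculus) for antiproliferative activity, read by sulforhodamine B assay, with a stated time of 48 h; a lower number here means a stronger inhibitor, a higher number a weaker inhibitor:
- compound 1 `CC1(C)[C@@H]2CC3=N[C@@H](CCC(=O)O)C(=O)O[C@@]3(C)[C@H]1C2`: 36000 nM
- compound 2 `C[C@@H]1N=C2C[C@@H]3C[C@@H](C3(C)C)[C@]2(C)OC1=O`: 145000 nM
- compound 3 `CC1(C)[C@H]2CC3=NCC(=O)O[C@]3(C)[C@@H]1C2`: > 300000 nM (a limit)

Compound 3 gives only a limit and no number: > 300000 nM. The series holds (the limit of > 300000 nM in this assay, at which 1 of the 3 values shown sits).

Unmeasured compound 4 `CC1(C)[C@@H]2CC3=NCC(=O)O[C@@]3(C)[C@H]1C2` is the mirror image of compound 3: the two compounds have the same atoms and bonds and differ only in configuration as drawn: 3 of 3 stereo elements differ (all stereocentres are inverted: mirror images); a stereocentre at a saturated ring carbon is drawn R in compound 3 and S in compound 4; a stereocentre at a saturated ring carbon is drawn R in compound 3 and S in compound 4; a stereocentre at a saturated ring carbon is drawn R in compound 3 and S in compound 4.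

Within the data shown here, the only measured step is a 4.0-fold higher number from compound 1 to compound 2 (0.61 log units; beyond the scatter). Among the measured compounds shown here, this is a change of substituent, hydrogen in place of carboxymethyl, so no measured step tests a change of configuration, and its size cannot be carried over. Compound 4 carries no carboxymethyl, so the closest number is that of compound 2 at 145000 nM. Since compound 3 is known only as a limit, any measurable change in this assay is expected toward a lower number, and it is expected to be small. Compound 4 may well return only a limit too.

The expected change is an at least 1.5-fold lower number from compound 3 to compound 4 (0.17 log units; that floor lies within the scatter).

Compound 4 is estimated at 200000 nM, with an expected range from 90000 nM to 300000 nM.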

Compound 4, half-maximal inhibitory concentration: 19000 nM
Compound 4: middle estimate off by 11-fold (1.02 log units), on the high side, and the stated range ends above it.
By their numbers in this assay, from the lowest: compounds 4 and 1 (each within the scatter of the next); then compound 2. At a limit, above all of these: compound 3.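

In this assay, configuration alone carries an at least 15-fold lower number from compound 3 to compound 4 (1.19 log units; beyond the scatter), a step read against a limit for compound 3, with nothing entering or leaving: the fact that compounds 3 and 4 differ only in the configuration as drawn On the same saturated ring carbon, methyl gives a further measured difference, with hydrogen in place of methyl accounting for a 7.6-fold lower number from compound 2 to compound 4 (0.88 log units; beyond the scatter). Hydrogen in place of 2-carboxyethyl gives a 1.9-fold lower number from compound 1 to compound 4 (0.28 log units; within the scatter), which is within the scatter, so this chain leaves no readable difference from hydrogen at that carbon.

Still open, on these data alone, is whether the inverted configuration has a similar effect when methyl or 2-carboxyethyl sits on that carbon, and how far compound 3 lies past its limit. An amine or an amide on the same saturated ring carbon also remains untested among the compounds shown here.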